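The source may report more compounds than this note shows. Statements on the series, on what has been measured and on what is new or still open speak of the compounds shown alone.

Measured compounds:
- compound 1 `CC1OC2(C=CC(=O)C=C2)N(c2nc(-c3ccc4ccccc4c3)nn2-c2ccccc2)C1=O`: 70 nM
- compound 2 `Cc1ccc(-n2nc(-c3ccc4ccccc4c3)nc2N2C(=O)C(C)OC23C=CC(=O)C=C3)cc1`: 100 nM
- compound 3 `Cc1ccc(-n2nc(-c3cccc4ccccc34)nc2N2C(=O)COC23C=CC(=O)C=C3)cc1`: 40 nM

All three were tested in a functional assay on MDA-MB-231 cells (Homo sapiens) for antiproliferative activity, with a stated time of 5 days; a lower number here means a stronger inhibitor, a higher number a weaker inhibitor. Compound 2 and compound 1 share a core and differ in one place: hydrogen in place of methyl on an aromatic carbon. The step is a 1.4-fold lower number from compound 2 to compound 1 (0.15 log units; within the scatter), so the two numbers cannot be ordered. Compound 3 carries a different core; the difference between the two cores of compound 3 and compound 2 is not broken down here. Compound 3 gives the lowest number of the three, but its gap to compound 1 is within the scatter, so it cannot be called the most potent; only its gap to compound 2 is beyond the scatter.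

Compound 4 `O=C1C=CC2(C=C1)OCC(=O)N2c1nc(-c2cccc3ccccc23)nn1-c1ccccc1` is the unmeasured member. Relative to compound 3 it shows (hydrogen in place of methyl on an aromatic carbon). For the measured compounds named here, this is the same change as the one from compound 2 to compound 1, at the same kind of place. With one earlier instance only, the expectation rests on that pair: the earlier step was a 1.4-fold lower number from compound 2 to compound 1 (0.15 log units; within the scatter), and a step of similar size, a 1.3-fold lower number from compound 3 to compound 4 (0.12 log units; within the scatter), is expected here. Compound 4 is therefore estimated at 30 nM in this assay, with a range of 12 nM to 75 nM, the range kept wide since the earlier step itself lay within the scatter.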

Compound 4, half-maximal inhibitory concentration: 50 nM
Beside the measured number, compound 4's estimate is 1.7-fold (0.22 log units) below it; measured number inside the range.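

In this assay the change from 4-methylphenyl to phenyl gives a 1.3-fold higher number from compound 3 to compound 4 (0.10 log units; within the scatter) and leaves the two numbers unordered. Set beside the earlier pair, the step shows no measurable dependence on which of the two cores carries the change: the same change on two cores in this assay, a 1.4-fold lower number (0.15 log units; within the scatter) from compound 2 to compound 1 and a 1.3-fold higher number (0.10 log units; within the scatter) from compound 3 to compound 4, 1.8-fold (0.25 log units) apart, within the scatter of two such steps. For the compounds shown here, this shows only that the change moved the number beyond the scatter in neither pair and that the two steps cannot be told apart; two pairs do not establish that the change is without effect in general, or that it would behave the same way on any other core.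

The aromatic position para to a large group carries only methyl or hydrogen in the compounds shown, so the outcome with a chlorine atom, a methoxy group, an amine or a carboxylic acid at that place remains open. Going by these compounds alone, the difference between the two cores also remains unresolved, as no pair here isolates any single part of it, and the contribution of each part to the numbers in this assay cannot be separated.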